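The compounds below may be only part of what the source reports. "The series", "measured", "known", "first", "only" and "open" are said of these compounds alone.

Measured compounds:
Compound 1 `Cc1cccc2c1nc(-c1c(F)cccc1F)n2Cc1c(F)cccc1F` in a toxicity assay on CCRF-CEM cells (Homo sapiens) for cytotoxicity (a higher number here means that more compound is tolerated, a lower number that less compound is tolerated), gives > 100 uM, a limit of the assay.
Compound 2 `Nc1cccc2c1nc(-c1c(F)cccc1F)n2Cc1c(F)cccc1F` in this assay gives 26.3 uM.
Compound 3 `CC(C)c1cccc2c1nc(-c1c(F)cccc1F)n2Cc1c(F)cccc1F` in this assay gives 27 uM.

Compound 3 and compound 2 sit within the scatter of each other, as the step of a 1.0-fold higher number from compound 2 to compound 3 (0.01 log units; within the scatter) shows; compound 1 gives only a limit. Compound 4 is `[N-]=[N+]=NCc1cccc2c1nc(-c1c(F)cccc1F)n2Cc1c(F)cccc1F`, carrying (azidomethyl in place of isopropyl on an aromatic carbon). Among the measured compounds shown here, the steps that bear on this position are an at least 3.8-fold lower number from compound 1 to compound 2 (0.58 log units; beyond the scatter) and an at least 3.7-fold lower number from compound 1 to compound 3 (0.56 log units; beyond the scatter), both beyond the scatter, while a 1.0-fold higher number from compound 2 to compound 3 (0.01 log units; within the scatter) is within it; three different groups at this carbon thus gave either a limit or two closely matched numbers. For the measured compounds named here, no step probes azidomethyl itself. Compound 4 is therefore expected to show a step of a 1.1-fold lower number from compound 3 to compound 4 (0.03 log units; within the scatter) that stays within the scatter. Compound 4 is estimated at 25 uM, with a range from 8 uM to 80 uM.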

Compound 4, half-maximal toxic concentration: > 100 uM
Compound 4 was reported as a limit; the forecaster's own chance of this, stated with the estimate: 10%; middle value at least 4.0-fold (0.60 log units) from the limit.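

With azidomethyl on this aromatic carbon, this assay gives an at least 3.7-fold higher number from compound 3 to compound 4 (0.56 log units; beyond the scatter) and an at least 3.8-fold higher number from compound 2 to compound 4 (0.58 log units; beyond the scatter), so the closely matched numbers of compound 2 and compound 3 do not hold for every group here. The result for compound 4 is a limit, and the step between compound 1 and compound 4 cannot be read, with both compounds at a limit: the limit of > 100 uM in this assay, at which 2 of the 4 values shown sit.

From the compounds shown here alone, it remains open what a longer chain or a carboxylic acid would give at this carbon. An aminomethyl group would show whether the step depends on the azido part of azidomethyl.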